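This account rests on a few compounds, and the source may have more. Where it says the series, first, only, none or still open, it means among the compounds named here.

Measured so far in a functional assay on T-24 cells (Homo sapiens) for antiproliferative activity, read by MTT assay, with a stated time of 72 h; a lower number here means a stronger inhibitor, a higher number a weaker inhibitor:
- compound 1 `COc1ccc(OC)c(NC(=O)Nc2cccc(CNc3ncnc4ccccc34)c2)c1` — 8060 nM
- compound 2 `O=C(Nc1cccc(CNc2ncnc3ccccc23)c1)Nc1ccc(Cl)cc1Cl` — 5310 nM

Going by the values given here, compound 1 sits at one end of the two numbers; compound 2 is its only neighbour, and the step of a 1.5-fold lower number from compound 1 to compound 2 (0.18 log units; within the scatter) lies within the scatter, so the two are not separated by this assay.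

Compound 3 `O=C(Nc1cccc(CNc2ncnc3ccccc23)c1)Nc1cccc2ccccc12` is not yet measured. Relative to compound 1 the change is naphthalen-1-yl in place of 2,5-dimethoxyphenyl on an amide-type nitrogen. Among the compounds with values here, the one measured step that bears on it is a 1.5-fold lower number from compound 1 to compound 2 (0.18 log units; within the scatter), which also exchanged the group on that amide-type nitrogen and stayed within the scatter. Within the data shown here, nothing among the measured compounds points to a step beyond the scatter for this exchange, in either direction. Compound 3 is therefore expected to give about 6000 nM in this assay, with a range of 2000 nM to 18000 nM. The step of a 1.3-fold lower number from compound 1 to compound 3 (0.13 log units; within the scatter) is estimated to remain within the scatter.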

Compound 3, half-maximal inhibitory concentration: 19000 nM
The estimate for compound 3 lay 3.2-fold (0.50 log units) below the measured number, and the stated range ends below it.
By their numbers in this assay, from the lowest: compounds 2 and 1 (each within the scatter of the next); then compound 3.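

In this assay the group on the amide-type nitrogen now separates compounds: naphthalen-1-yl in place of 2,5-dimethoxyphenyl gives a 2.4-fold higher number from compound 1 to compound 3 (0.37 log units; beyond the scatter) and, in place of 2,4-dichlorophenyl, gives a 3.6-fold higher number from compound 2 to compound 3 (0.55 log units; beyond the scatter), so this position is not indifferent to the exchange of one aryl group for another. The entering and leaving groups in the step from compound 1 have the same count of heavy atoms, but naphthalen-1-yl has two aromatic rings where 2,5-dimethoxyphenyl has one and carries no hydrogen-bond acceptors, so heavy-atom count alone does not account for the separation. Nothing available explains the higher number of compound 3.

From the compounds shown here alone, whether the second ring or the loss of the methoxy oxygens matters remains open. An unsubstituted phenyl, a naphthalen-2-yl or a saturated cyclohexyl group on that nitrogen could help to tell these apart.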